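Acetyl for allyl on the chain of compound 1

This account rests on a few compounds, and the source may have more. Where it says the series, first, only, none or still open, it means among the compounds named here.

Measured compounds:
compound 1 `C=CCCn1c(=O)c2[nH]cnc2n(CCC)c1=O`: 60 nM
compound 2 `CCCn1c(=O)n(CCC#N)c(=O)c2[nH]cnc21`: 15900 nM
compound 3 `CCCn1c(=O)n(CCCN(C)C)c(=O)c2[nH]cnc21`: 43200 nM

In an assay on Cerebral cortex for binding affinity to adenosine receptor A1 (Cavia porcellus), read by radioligand binding (a lower number here means a stronger inhibitor, a higher number a weaker inhibitor), compound 1 gives the lowest number of the three, and both other compounds lie beyond the scatter from it. Replacing the vinyl of that chain with cyano gives a 270-fold higher number from compound 1 to compound 2 (2.42 log units; beyond the scatter), and replacing it with (dimethylamino)methyl gives a 720-fold higher number from compound 1 to compound 3 (2.86 log units; beyond the scatter); between those two the step is a 2.7-fold higher number from compound 2 to compound 3 (0.43 log units; beyond the scatter). Compound 4 `CCCn1c(=O)n(CC(C)=O)c(=O)c2[nH]cnc21` carries the change (acetyl in place of allyl on a saturated chain carbon bound to an aromatic nitrogen). The two measured steps from compound 1 both exchange the vinyl end of the same chain for another group and both weaken binding strongly, so a large loss in this assay is expected here as well, of a size between those two, rather than none beyond the scatter. Compound 4 is therefore estimated at 8000 nM, within 1500 nM to 40000 nM, which corresponds to an expected step of a 130-fold higher number from compound 1 to compound 4 (2.12 log units; beyond the scatter).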

Compound 4, inhibition constant: 11400 nM
Compound 4: the middle estimate sits 1.4-fold (0.15 log units) below what was measured; the measured number falls inside the stated range.
By their numbers in this assay, from the lowest: compound 1; then compounds 4 and 2 (each within the scatter of the next); then compound 3.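

In this assay, acetyl in place of allyl keeps the same count of heavy atoms and a double bond outside aromatic rings, adds one hydrogen-bond acceptor, and still gives a large loss (a 190-fold higher number from compound 1 to compound 4 (2.28 log units; beyond the scatter)). A loss of this size therefore appears here without any change in the heavy-atom count. Compound 4 and compound 2 lie within the scatter of each other (a 1.4-fold lower number from compound 2 to compound 4 (0.14 log units; within the scatter)), while the 2-(dimethylamino)ethyl chain stays modestly weaker than acetyl (a 3.8-fold lower number from compound 3 to compound 4 (0.58 log units; beyond the scatter)).

Nothing shown gives a reason for these losses. On these data alone, it remains open whether a plain butyl chain would keep the binding of compound 1, and whether a chain ending in a hydroxyl or a carboxylic acid would fall with compound 4 and compound 2.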